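Swapping oxolan-3-yl for methyl on compound 2

A few compounds are considered here, and "the series" means these few. Any claim that something is new, unique, unknown or untested is made for them only; others in the source may bear on it.

Measured in a functional assay on A549 cells (Homo sapiens) for cytotoxicity, read by MTT assay, with a stated time of 72 h; on this read-out lower numbers stand for stronger inhibition and higher numbers for weaker inhibition:
Compound 1 `O=C(N/N=C/c1cc(Br)c(O)c(Br)c1)Nc1cc2c(Nc3ccc(F)c(Cl)c3)ncnc2cc1O[C@H]1CCOC1` gives 8910 nM
Compound 2 `CC(C)(C)c1cc(/C=N/NC(=O)Nc2cc3c(Nc4ccc(F)c(Cl)c4)ncnc3cc2O[C@H]2CCOC2)cc(C(C)(C)C)c1O` gives 19000 nM
Compound 3 `COc1cc2ncnc(Nc3ccc(F)c(Cl)c3)c2cc1NC(=O)N/N=C/c1cc(Br)c(O)c(Br)c1` gives 34600 nM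

In this assay compound 2 stands at 19000 nM which is a higher number than compound 1 at 8910 nM by more than the scatter, and it lies within the scatter of compound 3 at 34600 nM on the same read-out. Compound 4 `COc1cc2ncnc(Nc3ccc(F)c(Cl)c3)c2cc1NC(=O)N/N=C/c1cc(C(C)(C)C)c(O)c(C(C)(C)C)c1` has not yet been measured. It differs from compound 2 by methyl in place of oxolan-3-yl on an oxygen on an aromatic ring with methyl in place of oxolan-3-yl on an oxygen on an aromatic ring. One measured step makes this same replacement, a 3.9-fold higher number from compound 1 to compound 3 (0.59 log units; beyond the scatter) and it is modest but beyond the scatter. It comes from a single pair with different groups elsewhere, so a step of similar size toward a higher number is expected, with wide uncertainty. The estimated change is a 3.2-fold higher number from compound 2 to compound 4 (0.50 log units; beyond the scatter) in this assay as an expectation only. For compound 4 the expected value is 60000 nM with an estimated range of 25000 nM to 140000 nM in this read-out.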

Compound 4, half-maximal inhibitory concentration: 37100 nM
Compound 4: the middle estimate sits 1.6-fold (0.21 log units) above what was measured; the measured number falls inside the stated range.
By their numbers in this assay, from the lowest: compound 1; then compounds 2, 3 and 4 (each within the scatter of the next).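

In this assay, going by these compounds alone, the change from (oxolan-3-yl)oxy to methoxy can now be read on a second core, where it gives a 2.0-fold higher number from compound 2 to compound 4 (0.29 log units; within the scatter), so it no longer rests on the single pair of compound 1 and compound 3. The step on this second core lies within the scatter, whereas the earlier one lies beyond it, but the two steps cannot be told apart: the same change on two cores in this assay, a 3.9-fold higher number (0.59 log units; beyond the scatter) from compound 1 to compound 3 and a 2.0-fold higher number (0.29 log units; within the scatter) from compound 2 to compound 4, 2.0-fold (0.30 log units) apart, within the scatter of two such steps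

With only oxolan-3-yl and methyl shown on this oxygen on an aromatic ring, the compounds leave open how the number would respond to a longer chain or to a chain carrying an amine. They also leave open whether this change would read the same way on any core other than these two.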